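This account rests on a few compounds, and the source may have more. Where it says the series, first, only, none or still open, it means among the compounds named here.

Compound 2, `Cc1cccc(/C=C2\CCC/C(=C\c3ccccc3)C2=O)c1`, is the reference point of this account. In an assay on isolated protein for inhibition of Alpha glucosidase (Homo sapiens), with stated times of 5 min and 15 min, tested at 50 uM (a lower number here means less inhibition, a higher number more inhibition at the concentration tested (going by the name of the read-out)), compound 2 gives 47.9%, which places it second highest of the three numbers recorded. Its nearest neighbour is compound 1, `Cc1ccc(/C=C2\CCC/C(=C\c3ccccc3)C2=O)cc1`, which in this assay gives 34.1%; the single-point step a number 13.8 percentage points higher from compound 1 to compound 2 (beyond the scatter) lies beyond the scatter and is modest in size. The furthest number belongs to compound 3, `O=C1/C(=C/c2ccccc2)CCC/C1=C\c1ccc(O)c(O)c1`, which in this assay gives 90.7%.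

The unmeasured compound is compound 4, `O=C1/C(=C/c2ccccc2)CCC/C1=C\c1ccccc1Br`. Its difference from compound 2 is 2-bromophenyl in place of 3-methylphenyl on a double-bonded chain carbon bound to a double-bonded ring carbon. The only measured step at this position is the one between compound 1 and compound 2, where moving the methyl group on the phenyl ring changed the read-out by the amount shown in a number 13.8 percentage points higher from compound 1 to compound 2 (beyond the scatter). For the measured compounds named here, no measured compound carries a bromine, so there is no step that bears directly on the change to a 2-bromophenyl group. Going by the values given here, the one relevant step suggests that substitution on this phenyl ring can move the read-out by a modest amount in either direction, and compound 4 is therefore expected to stay near compound 2, with an expected step of a number 2.9 percentage points lower from compound 2 to compound 4 (within the scatter) that may not exceed the scatter. Compound 4 is estimated at 45%, within 25% to 65%.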

Compound 4, a percentage reported as inhibition, at one concentration (the size of the read-out at that concentration, not a potency): 46.8%
The estimate for compound 4 lay 1.8 percentage points below the measured number, within the range that was stated.
By their numbers in this assay, from the lowest: compound 1; then compounds 4 and 2 (each within the scatter of the next); then compound 3.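

Exchanging 3-methylphenyl for 2-bromophenyl on a double-bonded chain carbon bound to a double-bonded ring carbon gives a number 1.1 percentage points lower from compound 2 to compound 4 (within the scatter) in this assay, so this position holds a bromine-bearing ring with no read-out difference from compound 2 that stands clear of the scatter. For the compounds shown here, the same group gives a number 12.7 percentage points higher from compound 1 to compound 4 (beyond the scatter), which leaves 4-methylphenyl as the only one of these three rings set apart, while compound 3 at 90.7% remains far from all of them. No separate measurement bears on these numbers, so the data offer no explanation for them.

Since this change alters both the substituent and its place on the phenyl ring, the compounds shown cannot separate what the bromine contributes from what its place contributes. They also leave open how the read-out would respond to an amine or a carboxylic acid on this phenyl ring, and whether the high number of compound 3 depends on both of its hydroxyl groups or on only one.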